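The source may hold more compounds than are shown below. What is called first, only, known or untested is meant among the compounds shown, and "the series" means these compounds.

Compound 1 `c1ccc(-c2cccc3c2CCC3c2ncc[nH]2)nc1`: 53%
Compound 2 `c1cncc(-c2cccc3c2CCC3c2ncc[nH]2)c1`: 36%

Among the compounds with values here, in a functional assay on CHO cells for agonist activity at Alpha-1A adrenergic receptor (Homo sapiens), read by FLIPR and calcium flux (on this read-out lower numbers stand for smaller maximal responses and higher numbers for larger maximal responses), compound 2 gives 36%, the lowest of the two numbers measured; the nearest is compound 1 with 53%, and the step of a number 17 percentage points lower from compound 1 to compound 2 (beyond the scatter) is the only measured step. Compound 3 `c1cc(-c2cn[nH]c2)c2c(c1)C(c1ncc[nH]1)CC2` differs from compound 2 in one place: 1H-pyrazol-4-yl in place of pyridin-3-yl on an aromatic carbon. That single measured step exchanged one six-membered aromatic ring for another on an aromatic carbon, so it bears only loosely on a change to a five-membered aromatic ring; a modest shift in either direction remains plausible. Compound 3 is expected to give an estimated maximal response of 35%, with an expected range from 15% to 60%, which means an expected step of a number 1 percentage points lower from compound 2 to compound 3 (within the scatter).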

Compound 3, largest response reached (Emax), in percent of the reference or control that the assay uses: 84%
Compound 3: middle estimate off by 49 percentage points, on the low side; the whole stated range lies below it.
By their numbers in this assay, from the lowest: compound 2; then compound 1; then compound 3.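

In this assay, this aromatic carbon of the shared core tolerates more than a swap between pyridines had shown: the change to 1H-pyrazol-4-yl gives a number 48 percentage points higher from compound 2 to compound 3 (beyond the scatter) and a number 31 percentage points higher from compound 1 to compound 3 (beyond the scatter), both large steps where the earlier one was modest. The five-membered ring thus reaches a maximal response that neither pyridine reached here. No measured evidence accounts for this gain. As far as these compounds go, what stays open is whether the gain goes with the five-membered ring itself or with its hydrogen-bond donor. A 1-methylpyrazol-4-yl or a furan-3-yl group at this carbon would bear on that question.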